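Compound 3: replacing the 2,6-dimethoxyphenyl group

The source may hold more compounds than are shown below. What is called first, only, known or untested is meant among the compounds shown, and "the series" means these compounds.

Among the compounds with values here, the series has two measured members so far, compound 1 `O=C(Cc1csc2nc(-c3ccc(Br)cc3)cn12)N/N=C/c1ccccc1O` and compound 2 `COc1cccc(OC)c1/C=N/NC(=O)Cc1csc2nc(-c3ccc(Br)cc3)cn12`. In a functional assay on OVCAR-5 cells (Homo sapiens) for inhibition, read by sulforhodamine B assay, with a stated time of 48 h (a lower number here means a stronger inhibitor of growth, a higher number a weaker inhibitor of growth), compound 1 gives 31600 nM.

Compound 2 reads > 100000 nM in this assay, and this is a limit of the assay, not a number.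

Within the data shown here, the only measured step is an at least 3.1-fold higher number from compound 1 to compound 2 (0.50 log units; beyond the scatter), with 2,6-dimethoxyphenyl in place of 2-hydroxyphenyl on a carbon with a double bond to nitrogen.

Compound 3 `O=C(Cc1csc2nc(-c3ccc(Br)cc3)cn12)N/N=C/c1ccc(Cl)cc1Cl` has not yet been measured. It carries 2,4-dichlorophenyl in place of 2,6-dimethoxyphenyl at that same place: 2,4-dichlorophenyl in place of 2,6-dimethoxyphenyl on a carbon with a double bond to nitrogen.

Among the measured compounds shown here, no measured compound carries 2,4-dichlorophenyl, so the evidence here is indirect. The change removes the group that came in with an at least 3.1-fold higher number from compound 1 to compound 2 (0.50 log units; beyond the scatter), and a move back toward the level of compound 1 is therefore expected, with a lower number of about that size.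

The estimated step is an at least 2.8-fold lower number from compound 2 to compound 3 (0.45 log units; beyond the scatter).

In this assay the estimate for compound 3 is 35000 nM, with an expected range from 12000 nM to 100000 nM.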

Compound 3, concentration for total growth inhibition: 67600 nM
Compound 3: the middle estimate sits 1.9-fold (0.29 log units) below what was measured; measured number inside the range.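

In this assay, 2,4-dichlorophenyl in place of 2-hydroxyphenyl on a carbon with a double bond to nitrogen gives a 2.1-fold higher number from compound 1 to compound 3 (0.33 log units; beyond the scatter), so a second group besides 2,6-dimethoxyphenyl now leaves the number higher than that of compound 1. Compound 1 therefore holds the lowest number of the three, with its steps to both others beyond the scatter, while compound 3 shows that a ring with 0 hydrogen-bond donors can still give a number here rather than a limit. The change from 2,6-dimethoxyphenyl gives an at least 1.4-fold lower number from compound 2 to compound 3 (0.17 log units; that floor lies within the scatter), but the value of compound 2 is a limit of the assay and not a number, so this step is only a floor and compound 2 and compound 3 cannot be firmly ordered: the limit of > 100000 nM in this assay, at which 1 of the 3 values shown sits.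

From the compounds shown here alone, how a plain phenyl or a 2-aminophenyl would read on this carbon stays open, and so does whether the hydroxyl itself, rather than the wider pattern on the ring, goes with the lower number of compound 1. All three compounds share the same core, so the compounds shown say nothing about changes anywhere else in the molecule.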